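Swapping formyl for propylcarbonyl on compound 3

The source may report more compounds than this note shows. Statements on the series, on what has been measured and on what is new or still open speak of the compounds shown alone.

Four related compounds are in view here, and each is judged in a functional assay on the whole organism for positive allosteric modulation, with Mus musculus as the target; on this read-out lower numbers stand for an effect already at smaller amounts and higher numbers for an effect only at larger amounts of compound. Among the measured compounds shown here, compound 1 (`CCC(=O)N(c1cccc(C)c1)C1CCCC1N(C)C`) gives 25 mg/kg; 25 mg/kg (2 entries), the only real numbers in the set. Compound 2 (`CCC(=O)N(c1ccc(C)cc1)C1CCCCC1N(C)C`) gives > 50 mg/kg, which is a limit of the assay and not a number. Compound 3 (`CN(C)C1CCCC1N(C=O)c1ccc(Cl)c(Cl)c1`) gives > 50 mg/kg, which is likewise a limit. Compound 3 thus sits at the limit of > 50 mg/kg in this assay, at which 2 of the 3 values shown sit, with no measured dose of its own.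

Compound 4 (`CCCC(=O)N(c1ccc(Cl)c(Cl)c1)C1CCCC1N(C)C`) differs from compound 3 by one change, propyl in place of hydrogen on a carbonyl carbon. For the measured compounds named here, no measured pair of compounds isolates this change, so the data give no direct size for it. The reading of compound 1 at 25 mg/kg; 25 mg/kg (2 entries) shows that this family can give a measurable dose, while compound 2 shows that this is not assured. A modest shift towards smaller doses is therefore the most that seems reasonable, and nothing beyond the usual scatter is expected. The estimated change in this assay is an at least 1.2-fold lower number from compound 3 to compound 4 (0.09 log units; that floor lies within the scatter). Compound 4 is expected at 40 mg/kg, with an estimated range from 15 mg/kg to 100 mg/kg.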

Compound 4, dose for half-maximal effect: 0.9 mg/kg
Estimate against measurement, compound 4: 44-fold (1.65 log units) above; measured number below the stated range.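

In this assay, replacing the hydrogen on the carbonyl carbon with propyl, which turns formyl into propylcarbonyl, gives an at least 55-fold lower number from compound 3 to compound 4 (1.74 log units; beyond the scatter). Among the compounds shown here, this is the first single change in the set whose size can be read, and it shows that this carbonyl carbon, attached to the amide-type nitrogen, is highly sensitive: altering this one group is enough to move a compound from the limit of the assay to a low measured dose. Compound 3 gives > 50 mg/kg, which is a limit of the assay and not a number, so the step is a floor and the true change may be larger, because one end of it rests only on that limit: the limit of > 50 mg/kg in this assay, at which 2 of the 4 values shown sit.

As far as these compounds go, with only hydrogen and propyl compared at this carbonyl carbon, it remains open whether the effect grows steadily with chain length or peaks at a particular size, which ethyl or butyl in the same place on compound 4 could help settle. From the compounds shown here alone, it is also open whether a branched isopropyl group or a cyclopropyl ring would serve as well as the straight propyl chain.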